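The source may hold more compounds than are shown below. What is called first, only, known or untested is meant among the compounds shown, and "the series" means these compounds.

Measured compounds:
Compound 1 `C[C@H](c1ccc(C(=O)NCCC(=O)O)cc1)N1C(=O)C(c2ccc(F)cc2)=N[C@]12CC[C@@H](C(C)(C)C)CC2` gives 2500 nM in an assay on membranes from liver for displacement of a labelled ligand from Glucagon receptor (Mus musculus), read by scintillation counting, with a stated time of 60 min; on this read-out higher numbers stand for weaker inhibition and lower numbers for stronger inhibition.
Compound 2 `C[C@H](c1ccc(C(=O)NCCC(=O)O)cc1)N1C(=O)C(c2cccc(C3CC3)c2)=N[C@]12CC[C@@H](C(C)(C)C)CC2` gives 1700 nM in this assay.

Within the data shown here, on these two numbers compound 1 stands highest; the only measured step, a 1.5-fold lower number from compound 1 to compound 2 (0.17 log units; within the scatter), lies within the scatter, so the two values cannot be ordered. Compound 3 `C[C@H](c1ccc(C(=O)NCCC(=O)O)cc1)N1C(=O)C(c2cccc(F)c2)=N[C@]12CC[C@@H](C(C)(C)C)CC2` differs from compound 1 by 3-fluorophenyl in place of 4-fluorophenyl on a carbon with a double bond to nitrogen. Among the measured compounds shown here, the one step that bears on this, a 1.5-fold lower number from compound 1 to compound 2 (0.17 log units; within the scatter), also exchanges the aryl group on that carbon and stayed within the scatter, so for compound 3 no step beyond the scatter is expected in this assay. Compound 3 is therefore estimated at 2200 nM, range 1000 nM to 5000 nM, meaning an expected 1.1-fold lower number from compound 1 to compound 3 (0.06 log units; within the scatter).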

Compound 3, half-maximal inhibitory concentration: 4400 nM
Beside the measured number, compound 3's estimate is 2.0-fold (0.30 log units) below it; low and high end bracket the measured number.
By their numbers in this assay, from the lowest: compounds 2, 1 and 3 (each within the scatter of the next, the first and the last beyond it).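

In this assay, 3-fluorophenyl in place of 4-fluorophenyl gives a 1.8-fold higher number from compound 1 to compound 3 (0.25 log units; within the scatter), so these two placements of the fluorine cannot be ordered. Fluoro in place of cyclopropyl on an aromatic carbon gives a 2.6-fold higher number from compound 2 to compound 3 (0.41 log units; beyond the scatter), the first modest step beyond the scatter in these compounds, and it shows that the substituent on this aryl group can shift the number. No measurement on hand accounts for either step.

From the compounds shown here alone, it remains open whether a longer chain in place of cyclopropyl would extend this step. Going by these compounds, the effect of an amine or a methoxy group on the same aryl group is also open.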